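The compounds below may be only part of what the source reports. "The series", "measured", "known", "first", "only" and "open" are said of these compounds alone.

Measured compounds:
compound 1 `COc1cc(CNC(=O)/C=C/c2ccc(OCc3nc(C)c(C)nc3C)cc2)ccc1OCc1nc(C)c(C)nc1C` gives 7770 nM;
compound 2 `COc1cc(CNC(=O)/C=C/c2ccc(OCc3nc(C)c(C)nc3C)c(OC)c2)ccc1O` gives 10200 nM;
compound 3 `COc1cc(/C=C/C(=O)NCc2ccc(OCc3nc(C)c(C)nc3C)c(OC)c2)ccc1O` gives 13400 nM.

These three compounds were tested in a functional assay on SH-SY5Y cells (Homo sapiens) for cytotoxicity, read by MTT assay, with stated times of 24 h and 4 h; a higher number here means that more compound is needed for the effect, a lower number that less compound is needed. Compound 3 has the highest of the three numbers, but its nearest neighbour is compound 2, and the gap between the two lies within the scatter of this assay. The gap between compound 3 and compound 1 is also within the scatter, so none of the three can be set apart from the others on these numbers.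

Compound 4 `COc1cc(/C=C/C(=O)NCc2ccc(OCc3nc(C)c(C)nc3C)c(OC)c2)ccc1OCc1nc(C)c(C)nc1C` has not yet been measured. It differs from compound 3 in one place: (3,5,6-trimethylpyrazin-2-yl)methyl in place of hydrogen on an oxygen on an aromatic ring. Compound 1 already carries two such ethers and sits where it sits in this assay, so the presence of a second ether has not moved a value beyond the scatter among the compounds seen so far. Going by the values given here, no step between measured compounds that differ in only this one place is available, so the direction of the change is open. The expected step from compound 3 to compound 4 is a 1.4-fold lower number from compound 3 to compound 4 (0.15 log units; within the scatter), that is, none beyond the scatter. Compound 4 is therefore estimated at 9500 nM in this assay, within a range from 4000 nM to 22000 nM.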

Compound 4, half-maximal effective concentration: 11100 nM
For compound 4 the middle estimate is 1.2-fold (0.07 log units) below the measured one; low and high end bracket the measured number.
By their numbers in this assay, from the lowest: compounds 1, 2, 4 and 3 (each within the scatter of the next).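

With four compounds in hand, this assay now gives the first steps for this exchange: (3,5,6-trimethylpyrazin-2-yl)methyl in place of hydrogen on an oxygen on an aromatic ring gives a 1.2-fold lower number from compound 3 to compound 4 (0.08 log units; within the scatter) and, at the other hydroxy group, a 1.1-fold higher number from compound 2 to compound 4 (0.04 log units; within the scatter), so on these two compounds neither hydroxy group is shown to matter, as neither step lies beyond the scatter. Going by these compounds alone, the one other single change available here, methoxy in place of hydrogen on an aromatic carbon, gives a 1.4-fold higher number from compound 1 to compound 4 (0.15 log units; within the scatter) and also stays within the scatter, so compound 4 carrying both ethers and that methoxy cannot be set apart from compound 1, compound 2 or compound 3. No evidence in hand bears on these steps.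

What the compounds shown leave open is whether any other group on that oxygen, such as a simple methyl, a longer chain ending in an amine or a carboxylic acid, would give a step beyond the scatter. They also leave open whether the same exchange would stay within the scatter on a core without the methoxy group or the amide.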